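Nitro in Place of Chloro on an Arylhydrazone Series

A few compounds are considered here, and "the series" means these few. Any claim that something is new, unique, unknown or untested is made for them only; others in the source may bear on it.

Measured compounds:
compound 1 `CC1CC/C(=N\Nc2cccc(Cl)c2)c2ncc(C(=O)O)c(=O)n21` — 0.6 umol/kg
compound 2 `CC1CC/C(=N\Nc2ccc(Cl)cc2)c2ncc(C(=O)O)c(=O)n21` — 0.5 umol/kg

In a functional assay on the whole organism for inhibition, with Rattus norvegicus as the target (on this read-out higher numbers stand for an effect only at larger amounts of compound and lower numbers for an effect already at smaller amounts), compound 1 gives 0.6 umol/kg, the higher of the two numbers shown, and compound 2 gives 0.5 umol/kg; the step of a 1.2-fold lower number from compound 1 to compound 2 (0.08 log units; within the scatter) lies within the scatter, so the two values cannot be told apart. Compound 3 `CC1CC/C(=N\Nc2cccc([N+](=O)[O-])c2)c2ncc(C(=O)O)c(=O)n21` has not been measured in this assay. It differs from compound 1 by nitro in place of chloro on an aromatic carbon. For the measured compounds named here, no measured step bears on this change: the single step on record swaps the position of chloro, not the group itself, and it was within the scatter. Without a comparison the size and direction of the step to compound 3 cannot be read from the data. Compound 3 is therefore expected to give 0.6 umol/kg, with a range from 0.2 umol/kg to 2 umol/kg. This estimate means a step of no change at the digits printed from compound 1 to compound 3 (within the scatter), expected to stay near the value of compound 1.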

Compound 3, dose for 50% inhibition: 0.5 umol/kg
Compound 3: middle estimate off by 1.2-fold (0.08 log units), on the high side, and the stated range covers the measured number.
By their numbers in this assay, from the lowest: compounds 2, 3 and 1 (each within the scatter of the next).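

In this assay, nitro in place of chloro on an aromatic carbon, meta to a large group, gives a 1.2-fold lower number from compound 1 to compound 3 (0.08 log units; within the scatter) and so no change that can be told from the scatter. The earlier pair only moved chloro around the ring, whereas this step replaces the group itself: one heavy atom leaves, and three enter with two hydrogen-bond acceptors. The result shows that this place on the ring can carry either group without a readable difference in the dose needed, though no measurement on hand offers an explanation for this.

The compounds shown leave open whether an amine or a methoxy group at this place would also stay within the scatter of compound 1. They also leave open whether nitro would match chloro at the place it holds in compound 2.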